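The source may report more compounds than this note shows. Statements on the series, on what has been measured and on what is new or still open speak of the compounds shown alone.

Measured so far:
compound 1 `Cc1nc2c(OCc3ccccc3)cccn2c1Cl` — in a functional assay on the whole organism (stomach) for inhibition, with Canis familiaris (Canis lupus familiaris) as the target, at a dose of 5 mg/kg by the intravenous route (on this read-out higher numbers stand for a stronger effect at the one dose given and lower numbers for a weaker effect), compound 1 gives 37%
compound 2 `Cc1nc2c(OCc3ccccc3)cccn2c1Br` — in this assay compound 2 gives 63%

For the measured compounds named here, compound 2 holds the highest of the two numbers; its nearest neighbour is compound 1, and the one measured step, a number 26 percentage points higher from compound 1 to compound 2 (beyond the scatter), is bromo in place of chloro on an aromatic carbon. Compound 3 `CC(=O)OCc1c(C)nc2c(OCc3ccccc3)cccn12` is the next compound to be measured. Its change from compound 2 is acetoxymethyl in place of bromo on an aromatic carbon. Going by the values given here, no measured step involves an acetoxymethyl group, so the halogen swap is the only comparison available, and it bears on the present change only in showing that the group at this carbon is not indifferent. A wide band is therefore set. Compound 3 is estimated at 45%, with a range from 15% to 75%. This estimate amounts to an expected step of a number 18 percentage points lower from compound 2 to compound 3 (beyond the scatter), which reflects the lack of a comparable measured change rather than a predicted loss.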

Compound 3, a percentage reported as inhibition, in the whole organism at one dose (the size of the read-out at that dose, not a potency): 87%
For compound 3 the middle estimate is 42 percentage points below the measured one; the whole stated range lies below it.
By their numbers in this assay, from the lowest: compound 1; then compound 2; then compound 3.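

In this assay the step of a number 24 percentage points higher from compound 2 to compound 3 (beyond the scatter), together with a number 50 percentage points higher from compound 1 to compound 3 (beyond the scatter), shows that a response at this aromatic carbon is not confined to halogens. The bromo atom can give way to an acetoxymethyl group, with five heavy atoms and a carbonyl, and the number still rises, so compound 3 stands highest of the three. No measurement shown here explains this rise.

Going by these compounds, it remains open which part of the acetoxymethyl group matters, and a hydroxymethyl, a methoxymethyl or an aminomethyl group at this carbon would help to separate the contributions of the ester and the chain. Each number also comes from a single dose, so the order of the three compounds gives the size of the effect at that dose and leaves their potency open.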